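This account rests on a few compounds, and the source may have more. Where it says the series, first, only, none or still open, it means among the compounds named here.

In a functional assay on A549 cells (Homo sapiens) for antiproliferative activity, with a stated time of 72 h (on this read-out higher numbers stand for weaker inhibition and lower numbers for stronger inhibition), compound 1 `COc1ccccc1/C=C/c1nc(Nc2ccccc2Cl)c2ccccc2n1` gives > 25000 nM, which is a limit of the assay and not a number. Among the compounds with values here, compound 2 `COc1ccccc1/C=C/c1nc(Nc2ccc(O)cc2)c2ccccc2n1` gives 13000 nM, the only true number so far, so it has no measured neighbour to be ranked against with any precision. Compound 3 `Oc1ccc(Nc2nc(/C=C/c3cccc(Cl)c3)nc3ccccc23)cc1` keeps the 4-hydroxyphenyl on nitrogen from compound 2 and changes the other side of the molecule: 3-chlorophenyl in place of 2-methoxyphenyl on a double-bonded chain carbon bound to a double-bonded chain carbon. Here 3-chlorophenyl takes the place of 2-methoxyphenyl on a double-bonded chain carbon bound to a double-bonded chain carbon. Within the data shown here, only one measured step is available, an at least 1.9-fold lower number from compound 1 to compound 2 (0.28 log units; that floor lies within the scatter), and it changed the group on a nitrogen on an aromatic ring, not the group on the chain. Among the measured compounds shown here, it therefore says little about this new change, and no measured step shows what swapping these two groups does. With so little to go on, no change beyond the scatter is expected in this assay, and the expected result is a 1.4-fold lower number from compound 2 to compound 3 (0.16 log units; within the scatter). For compound 3 the estimated value is 9000 nM, with an expected range from 2500 nM to 25000 nM.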

Compound 3, half-maximal inhibitory concentration: 14800 nM
The estimate for compound 3 lay 1.6-fold (0.22 log units) below the measured number; measured number inside the range.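

In this assay, putting 3-chlorophenyl in place of 2-methoxyphenyl on a double-bonded chain carbon bound to a double-bonded chain carbon gives a 1.1-fold higher number from compound 2 to compound 3 (0.06 log units; within the scatter). Within the data shown here, this is the only measured step at this place on the chain, and it shows that this exchange, which also removes the hydrogen-bond acceptor of the leaving group, leaves the two compounds indistinguishable in this assay while the 4-hydroxyphenyl on nitrogen stays the same. One of the values in this small set, that of compound 1, is a limit and not a number: the limit of > 25000 nM in this assay, at which 1 of the 3 values shown sits.

Since the substituent and its place on the ring both differ between compound 2 and compound 3, this single pair cannot show what either difference does alone. The compounds shown also leave open whether a quite different group at this place, such as a phenyl ring bearing an amine or a carboxylic acid, or a longer chain, would shift the number beyond the scatter in either direction.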